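Thiocarbonyl ring variation: working notes on three analogues

The source may report more compounds than this note shows. Statements on the series, on what has been measured and on what is new or still open speak of the compounds shown alone.

Measured so far:
- Compound 1 `N/C(=N\NC(=S)N1CCOCC1)c1ccccn1`, in a functional assay on A-375 cells (Homo sapiens) for cytotoxicity, read by MTT assay, with a stated time of 72 h, tested at 1 uM; on this read-out higher numbers stand for more inhibition of growth at the one concentration tested and lower numbers for less inhibition of growth: 26.8%
- Compound 2 `N/C(=N\NC(=S)N1CCSCC1)c1ccccn1`, in this assay: 34%

Compound 2 stands highest of the two numbers in this assay, though its nearest neighbour, compound 1, sits within the scatter: the step of a number 7.2 percentage points higher from compound 1 to compound 2 (within the scatter) is too small to count as a real difference, so nothing separates the two on this read-out.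

The next compound to be measured is compound 3 `N/C(=N\NC(=S)N1CCCCC1)c1ccccn1`. The change from compound 2 is piperidin-1-yl in place of thiomorpholin-4-yl on a thiocarbonyl carbon. Within the data shown here, only one measured step bears on this position, the change from compound 1 to compound 2, which replaced the ring oxygen of morpholin-4-yl with the ring sulfur of thiomorpholin-4-yl and gave a number 7.2 percentage points higher from compound 1 to compound 2 (within the scatter), within the scatter. That earlier swap at the same position left the read-out essentially unchanged, so for the present swap no step beyond the scatter is expected in this assay in either direction.

For compound 3 the expected value in this assay is 32%, with a range from 20% to 45%. The expected step of a number 2 percentage points lower from compound 2 to compound 3 (within the scatter) is therefore small and within the scatter.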

Compound 3, percent growth inhibition at one concentration: 72.5%
The estimate for compound 3 lay 40.5 percentage points below the measured number, outside the stated range (above it).
By their numbers in this assay, from the lowest: compounds 1 and 2 (each within the scatter of the next); then compound 3.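

In this assay, among these compounds, (this assay) the position on the thiocarbonyl carbon proves far from indifferent to the ring it carries: piperidin-1-yl in place of thiomorpholin-4-yl gives (a number 38.5 percentage points higher from compound 2 to compound 3 (beyond the scatter)), and piperidin-1-yl in place of morpholin-4-yl gives (a number 45.7 percentage points higher from compound 1 to compound 3 (beyond the scatter)), whereas the only earlier step at this position stayed within the scatter. Among these three compounds the split runs between the two rings with 2 hetero atoms, compound 1 and compound 2, which this read-out does not separate, and the ring with 1 hetero atom in compound 3, and none of the three goes against that split. Nothing available here bears on the reason for this gap.

The compounds shown leave open whether the gain follows from the absence of a second ring hetero atom in general or belongs to piperidin-1-yl itself, a question that a piperazine ring, a pyrrolidine ring, an azepane ring or an open diethylamino group at the same place would address. They also leave open whether the gap seen at the one concentration tested holds across a range of concentrations.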